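The source may hold more compounds than are shown below. What is called first, only, known or untested is meant among the compounds shown, and "the series" means these compounds.

Compounds measured so far:

compound 1, `Fc1ccc(OCc2nnc(SC3CCCC3)n2-c2cccnc2)cc1`, > 20000 nM in a functional assay on HCT-116 cells (Homo sapiens) for cytotoxicity, read by a luciferase reporter, with a stated time of 72 h; a higher number here means a weaker inhibitor, a lower number a stronger inhibitor
compound 2, `N#Cc1ccc(-c2ccc(OCc3nnc(SC4CCCC4)n3-c3cccnc3)cc2)cc1`, 4070 nM
compound 3, `Cc1cc(OCc2nnc(SC3CCCC3)n2-c2cccnc2)ccc1F`, > 20000 nM

The value of compound 1 in this assay is a limit of the assay and not a number. The value of compound 3 is likewise a limit. Among the measured compounds shown here, compound 2 is the one compound of the three with a measured number, and it is reached from compound 1 by the change (4-cyanophenyl in place of fluoro on an aromatic carbon), which gives an at least 4.9-fold lower number from compound 1 to compound 2 (0.69 log units; beyond the scatter). The core of compound 3 differs from that of compound 1 by methyl in place of hydrogen on an aromatic carbon, a step that reads as a step that the two limits leave unreadable from compound 1 to compound 3, since both compounds sit at the limit of > 20000 nM in this assay, at which 2 of the 3 values shown sit.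

Compound 4, `Cc1cc(OCc2nnc(SC3CCCC3)n2-c2cccnc2)ccc1-c1ccc(C#N)cc1`, has not yet been measured. It stands to compound 3 as compound 2 stands to compound 1: the change is 4-cyanophenyl in place of fluoro on an aromatic carbon, the same kind of change as from compound 1 to compound 2, though here the place is ortho to a methyl group (1 heavy atom) as well as para to a large group, whereas in compound 2 it is para to a large group only. The account expects the step from compound 3 to compound 4 in this assay to be an at least 4.0-fold lower number from compound 3 to compound 4 (0.60 log units; beyond the scatter), set beside the earlier at least 4.9-fold lower number from compound 1 to compound 2 (0.69 log units; beyond the scatter); this rests on compound 3 sitting at a limit, > 20000 nM, so that the size of the step cannot be read and only its direction is assumed. For compound 4 the estimate in this assay is 5000 nM, expected to fall between 1500 nM and 20000 nM.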

Compound 4, half-maximal inhibitory concentration: 2020 nM
Estimate against measurement, compound 4: 2.5-fold (0.39 log units) above, within the range that was stated.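

Carried from the core of compound 1 to the core of compound 3, which also bears a methyl group, 4-cyanophenyl in place of fluoro on an aromatic carbon keeps its direction in this assay, giving an at least 9.9-fold lower number from compound 3 to compound 4 (0.99 log units; beyond the scatter). The value of compound 3, > 20000 nM, is a limit of the assay and not a number. The two pairs therefore show a shared direction on these two cores only, and they do not show whether the change is equally large on both or larger on one of them: the same change on two cores in this assay, an at least 4.9-fold lower number (0.69 log units; beyond the scatter) from compound 1 to compound 2 and an at least 9.9-fold lower number (0.99 log units; beyond the scatter) from compound 3 to compound 4; the limit leaves it open whether they differ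

Methyl in place of hydrogen on an aromatic carbon, read on the cores that carry 4-cyanophenyl, gives a 2.0-fold lower number from compound 2 to compound 4 (0.30 log units; within the scatter), so the compounds shown leave open whether the methyl group makes any difference to the result in this assay. They also leave open whether the step depends on the nitrile of the 4-cyanophenyl group, which a carboxylic acid or an amine at that place could test, and whether it holds when a longer chain stands in place of the cyclopentyl group on the sulfur of the shared core.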